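This account rests on a few compounds, and the source may have more. Where it says the series, first, only, none or still open, it means among the compounds named here.

Measured in a functional assay on A2780 cells (Homo sapiens) for antiproliferative activity, read by MTT assay, with a stated time of 72 h; a lower number here means a stronger inhibitor, a higher number a weaker inhibitor:
- compound 1 `CCNC(=O)NOCc1ccc(/C=C/C(=O)NO)cc1`: 35400 nM
- compound 2 `Cc1cc(C)cc(NC(=O)NOCc2ccc(/C=C/C(=O)NO)cc2)c1`: 2010 nM

Compound 1 holds the higher of these two numbers in this assay. Going by the values given here, the only measured step is an 18-fold lower number from compound 1 to compound 2 (1.25 log units; beyond the scatter), which is large and beyond the scatter. Next comes compound 3 `O=C(/C=C/c1ccc(CONC(=O)c2ccccc2)cc1)NO`, with this change from compound 1: phenyl in place of ethylamino on a carbonyl carbon. The measured step bears on this only in part. It also brings in an aromatic ring, but on an amide-type nitrogen rather than on a carbonyl carbon, and compound 3 has no methyl groups on its ring. One step is thin support, so a lower number is expected in this assay, though by less than the step to compound 2 at 2010 nM. The expected change is a 5.9-fold lower number from compound 1 to compound 3 (0.77 log units; beyond the scatter). For compound 3 the estimated value is 6000 nM, with an expected range of 1800 nM to 20000 nM.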

Compound 3, half-maximal inhibitory concentration: 2080 nM
Compound 3: the middle estimate sits 2.9-fold (0.46 log units) above what was measured, and the stated range covers the measured number.
By their numbers in this assay, from the lowest: compounds 2 and 3 (each within the scatter of the next); then compound 1.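

In this assay, phenyl in place of ethylamino on a carbonyl carbon gives a 17-fold lower number from compound 1 to compound 3 (1.23 log units; beyond the scatter), a large step. This shows that a ring placed directly on the carbonyl carbon is enough for a large step, with no amide-type nitrogen between the two and no methyl groups on the ring; compound 2 at 2010 nM and compound 3 at 2080 nM lie within the scatter of each other. No measurement on hand accounts for the step.

Still open, from the compounds shown here alone, is whether the ring itself matters at this position, which a cyclohexyl group or a longer alkyl chain on the carbonyl carbon would test. Also open, going by these compounds, is how a pyridine ring, or a phenyl ring bearing a chlorine or a methoxy group, would read here.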